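Benzylamino in place of diethylamino on the shared core

The source may hold more compounds than are shown below. What is called first, only, known or untested is meant among the compounds shown, and "the series" means these compounds.

Within the data shown here, compound 2 `CCN(CC)c1c(S(=O)(=O)c2ccc(C)cc2)cnc2ccccc12` has the higher of the two numbers measured so far: in an assay on isolated protein for displacement of a labelled ligand from metabotropic glutamate receptor 5 (Homo sapiens), with a stated time of 60 min (on this read-out higher numbers stand for weaker inhibition and lower numbers for stronger inhibition), compound 2 gives 201 nM, whereas compound 1 `CC1CCN(c2c(S(=O)(=O)c3ccc(Cl)c(Cl)c3)cnc3ccc(F)cc23)CC1` gives 68.2 nM, a gap beyond the usual scatter. Compound 3 `Cc1ccc(S(=O)(=O)c2cnc3ccccc3c2NCc2ccccc2)cc1` is not yet measured; it differs from compound 2 by benzylamino in place of diethylamino on an aromatic carbon. Among the measured compounds shown here, no measured pair shows this exchange, so the size of the step is uncertain; a small move toward stronger inhibition, or none beyond the scatter, is expected, as the step of a 1.3-fold lower number from compound 2 to compound 3 (0.13 log units; within the scatter) expresses. Compound 3 is estimated at 150 nM, within 40 nM to 500 nM.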

Compound 3, inhibition constant: 198 nM
Beside the measured number, compound 3's estimate is 1.3-fold (0.12 log units) below it, and the stated range covers the measured number.
By their numbers in this assay, from the lowest: compound 1; then compounds 3 and 2 (each within the scatter of the next).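

In this assay, benzylamino in place of diethylamino on this aromatic carbon, opposite the ring nitrogen, gives a 1.0-fold lower number from compound 2 to compound 3 (0.01 log units; within the scatter), so the larger group, with its aromatic ring and hydrogen-bond donor, leaves the number within the scatter. Among these compounds, this is the first exchange at this position that can be read, since the earlier compounds offered no pair differing in one place. Nothing at hand accounts for this result. Still open, from the compounds shown here alone, is how a morpholine or a longer chain such as phenethylamino would read here, and whether a methyl on the benzylamino nitrogen would shift the number.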